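Pyrimidine in place of pyrazole on a weak urea

A few compounds are considered here, and "the series" means these few. Any claim that something is new, unique, unknown or untested is made for them only; others in the source may bear on it.

Measured so far:
- compound 1, `CCOC(=O)c1ccc(NC(=O)NCc2cc[nH]n2)cc1`: 69000 nM
- compound 2, `CN(C1CCCC1)S(=O)(=O)c1ccc(NC(=O)NCc2ccncc2)cc1`: 123 nM
- compound 3, `O=C(NCc1cn[nH]c1)Nc1ccc(S(=O)(=O)c2ccc(Cl)cc2)cc1`: 23 nM

All three compounds are ureas tested in an assay on isolated protein for activation of Nicotinamide phosphoribosyltransferase (Homo sapiens); on this read-out lower numbers stand for an effect already at smaller amounts and higher numbers for an effect only at larger amounts of compound. Compound 1 stands at the highest number of the three; compound 2 lies well below it and compound 3 lower still, both gaps far beyond the usual scatter, so compound 1 is clearly the weakest of the measured set. For the measured compounds named here, compounds 2 and 3 each carry a different aryl portion as well as a different heteroaryl on the chain, so no single step between measured compounds isolates the heteroaryl.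

Compound 4, `CCOC(=O)c1ccc(NC(=O)NCc2ccncn2)cc1`, keeps the core of compound 1 and changes only the heteroaryl: pyrimidin-4-yl in place of 1H-pyrazol-3-yl on a saturated chain carbon bound to an amide-type nitrogen. A six-membered aza-aromatic on that chain carbon appears in compound 2, which gives 123 nM, but its other end differs too. In this assay a modest step toward stronger activation is expected, a 2.8-fold lower number from compound 1 to compound 4 (0.44 log units; beyond the scatter), with wide uncertainty. The estimate for compound 4 in this assay is 25000 nM, within 4000 nM to 120000 nM.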

Compound 4, half-maximal effective concentration: 13600 nM
For compound 4 the middle estimate is 1.8-fold (0.26 log units) above the measured one; measured number inside the range.
By their numbers in this assay, from the lowest: compound 3; then compound 2; then compound 4; then compound 1.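

For the compounds shown here, with everything else held fixed, pyrimidin-4-yl in place of 1H-pyrazol-3-yl on a saturated chain carbon bound to an amide-type nitrogen gives a 5.1-fold lower number from compound 1 to compound 4 (0.71 log units; beyond the scatter) in this assay, the first reading that isolates this position. The entering ring has 0 hydrogen-bond donors where the leaving ring has 1, so in this pair a donor on the ring is not needed for the number to fall. No measurement here explains the size or the direction of this step.

On these data alone, it remains open whether a plain phenyl ring or a pyridin-3-yl ring at this position would give a similar number, which would help show how much the ring nitrogens matter. As far as these compounds go, it is also open whether the same swap would give a similar step with a different group in place of the ethyl ester.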